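The compounds below may be only part of what the source reports. "The series", "measured", "known", "first", "only" and "open" are said of these compounds alone.

Going by the values given here, in an assay on HEK293 cells for displacement of a labelled ligand from 5-hydroxytryptamine receptor 7 (Rattus norvegicus), read by radioligand binding (a higher number here means a weaker inhibitor, a lower number a stronger inhibitor), compound 2 `CC(C)n1nc2c(c1-c1ccccc1)CCNCC2` gives 28 nM, the lowest of the two numbers known so far. Its companion compound 1 `CCn1nc2c(c1-c1ccccc1)CCNCC2` gives 140 nM in this assay. Among the compounds with values here, the one step available, a 5.0-fold lower number from compound 1 to compound 2 (0.70 log units; beyond the scatter), lengthened the chain on the aromatic nitrogen and brought a modest gain. Compound 3 `CC(C)(C)n1nc2c(c1-c1ccccc1)CCNCC2` carries that change one bond further out: methyl in place of hydrogen on a saturated chain carbon bound to an aromatic nitrogen and two saturated chain carbons. Since the earlier step favoured the larger group, a smaller move in the same direction is expected for compound 3, namely a 1.4-fold lower number from compound 2 to compound 3 (0.15 log units; within the scatter). Compound 3 is therefore estimated at 20 nM, within 6 nM to 70 nM.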

Compound 3, inhibition constant: 30 nM
For compound 3 the middle estimate is 1.5-fold (0.18 log units) below the measured one, and the stated range covers the measured number.
By their numbers in this assay, from the lowest: compounds 2 and 3 (each within the scatter of the next); then compound 1.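

In this assay, the further methyl on this saturated chain carbon, isopropyl to tert-butyl, leaves the two numbers within the scatter (a 1.1-fold higher number from compound 2 to compound 3 (0.03 log units; within the scatter)), so the earlier gain does not extend with this methyl. The tert-butyl group still keeps the gain over ethyl on the aromatic nitrogen (a 4.7-fold lower number from compound 1 to compound 3 (0.67 log units; beyond the scatter)), so this position accepts tert-butyl as well as isopropyl. Nothing at hand bears on the reason for this result. Still open, as far as these compounds go, is how a longer chain, a cyclopropyl group or a hydroxyethyl chain on the aromatic nitrogen would read.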